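Swapping Methyl for Chloro on a Fused Core

The compounds below may be only part of what the source reports. "The series", "measured", "known", "first", "only" and "open" are said of these compounds alone.

Compound 1 `COc1cc(C)nc2n/c(=N/C(=O)c3c(-c4ccc(Cl)cc4Cl)noc3C)sn12` was tested in a functional assay on the whole organism for inhibition, with Brassica napus as the target, with a stated time of 72 h, tested at 100 mg/L; on this read-out higher numbers stand for more inhibition of growth at the one concentration tested and lower numbers for less inhibition of growth. In this assay, going by the values given here, compound 1 gives 80.6%, the higher of the two numbers measured so far. Among the compounds with values here, the only other measured compound, compound 2 `COc1cc(Cl)nc(NC(=S)NC(=O)c2c(-c3ccc(Cl)cc3Cl)noc2C)n1`, is built with a different arrangement of core and linker; in this assay compound 2 gives 61%, a number that lies beyond the usual scatter below that of compound 1. Within the data shown here, no measured pair differs in a single place, so no measured step is at hand to show how one small change shifts the read-out.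

Compound 3 `COc1cc(Cl)nc2n/c(=N/C(=O)c3c(-c4ccc(Cl)cc4Cl)noc3C)sn12` differs from compound 1 by one change: chloro in place of methyl on an aromatic carbon. Among the measured compounds shown here, with no measured pair showing what a change of this kind does, the expectation for compound 3 rests on compound 1 and is held near that value. The step that this estimate means, a number 4.6 percentage points lower from compound 1 to compound 3 (within the scatter), is expected to stay within the scatter, with a slight lean downward. The estimated value for compound 3 in this assay is 76%, within a range from 55% to 92%.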

Compound 3, percent growth inhibition at one concentration: 70.8%
Estimate against measurement, compound 3: 5.2 percentage points above, and the stated range covers the measured number.
By their numbers in this assay, from the lowest: compounds 2, 3 and 1 (each within the scatter of the next, the first and the last beyond it).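

Going by these compounds alone, the first single-place pair in the set concerns the aromatic carbon next to the ring nitrogen, on the six-membered aromatic ring with 2 nitrogen. In this assay, chloro in place of methyl at this carbon gives a number 9.8 percentage points lower from compound 1 to compound 3 (within the scatter), so this one swap produces no difference that can be told apart from the ordinary spread of repeated measurements. Methyl and chloro can therefore be treated as equivalent here on this read-out, which is something the earlier comparison of compound 1 and compound 2 could not show, since those two differ in more than one place; no measurement bearing on what lies behind this result is available.

From the compounds shown here alone, whether the same holds for an amine, a carboxylic acid or a longer alkyl chain on this carbon remains open, as one pair of small groups says little about larger or charged ones. Also open, going by these compounds, is whether methyl and chloro would stay equivalent at other concentrations, on other plant species, or with a group other than methoxy on the same ring.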